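The source may report more compounds than this note shows. Statements on the series, on what has been measured and on what is new or still open speak of the compounds shown alone.

Measured in a functional assay on NCI-H1975 cells (Homo sapiens) for inhibition, read by sulforhodamine B assay, with a stated time of 48 h; on this read-out higher numbers stand for weaker inhibition of growth and lower numbers for stronger inhibition of growth:
Compound 1, `CC(C)c1cc(C(=O)Nc2ccc(NC(=O)CCCCCCC(=O)NO)cc2)c(O)cc1O`, gives > 10000 nM, which is a limit of the assay rather than a number.
Compound 2, `CC(C)c1cc(C(=O)N(c2ccc(NC(=O)CCCCCCC(=O)NO)cc2)C(C)C)c(O)cc1O`, gives > 10000 nM, likewise a limit.
Compound 3, `CC(C)c1cc(C(=O)N(C)c2ccc(NC(=O)CCCCCCC(=O)NO)cc2)c(O)cc1O`, gives 690 nM.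

Within the data shown here, compound 3 therefore holds the only real number among the three; the other two rest at the limit of > 10000 nM in this assay, at which 2 of the 3 values shown sit. Compound 4, `CC(C)c1cc(C(=O)N(C)c2ccc(NC(=O)CCCCCCCCC(=O)NO)cc2)c(O)cc1O`, keeps the core of compound 3 and differs only in the chain carrying the hydroxycarbamoyl group: 2-(hydroxycarbamoyl)ethyl in place of hydroxycarbamoyl on a saturated chain carbon, six bonds along the chain from a carbonyl carbon. Among the measured compounds shown here, none of the measured steps touches this chain: an at least 14-fold lower number from compound 1 to compound 3 (1.16 log units; beyond the scatter) and an at least 14-fold lower number from compound 2 to compound 3 (1.16 log units; beyond the scatter) both concern the group on the amide-type nitrogen, which compound 4 keeps as methyl. With nothing measured bearing on the change, no step beyond the scatter is expected in this assay in either direction. Compound 4 is thus estimated at 700 nM, between 250 nM and 2500 nM, an expected step of a 1.0-fold higher number from compound 3 to compound 4 (0.01 log units; within the scatter).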

Compound 4, concentration for 50% growth inhibition: 210 nM
Compound 4: middle estimate off by 3.3-fold (0.52 log units), on the high side; measured number outside the range, below it.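

In this assay the chain carrying the hydroxycarbamoyl group turns out to matter: there is a 3.3-fold lower number from compound 3 to compound 4 (0.52 log units; beyond the scatter) when 2-(hydroxycarbamoyl)ethyl stands in place of hydroxycarbamoyl. The earlier steps shown here spoke only of the group on the amide-type nitrogen, whereas this one shows that growth inhibition also shifts with the chain, while methyl stays on that nitrogen. Nothing measured here explains the shift.

From the compounds shown here alone, whether a still longer chain lowers the number further, or a shorter one raises it, remains open. So does whether an amine or a carboxylic acid could take the place of the hydroxycarbamoyl group.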